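The source may report more compounds than this note shows. Statements on the series, on what has been measured and on what is new or still open speak of the compounds shown alone.

Working notes on the series. In a functional assay on A549 cells (Homo sapiens) for antiproliferative activity, read by sulforhodamine B assay, with a stated time of 48 h (on this read-out higher numbers stand for weaker inhibition and lower numbers for stronger inhibition), compound 1 `COc1ccc2nc(-c3ccc(N/C=C\C(=O)c4ccc(OC)c(O)c4)c(C)c3)sc2c1` gives 18000 nM as its reading. Compound 2 `COc1cc(C(=O)/C=C\Nc2ccc(-c3nc4cc(OC)c(OC)c(OC)c4s3)cc2C)cc([N+](=O)[O-])c1OC` gives 17400 nM there, and compound 3 `COc1ccc2nc(-c3ccc(N/C=C\C(=O)c4ccc(OC)c(O)c4)cc3)sc2c1` gives 12800 nM in the same read-out. Compound 1 stands level with both, each of them lying within the scatter of it.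

Compound 4 `COc1ccc2nc(-c3ccc(N/C=C\C(=O)c4ccc(OC)c([N+](=O)[O-])c4)c(C)c3)sc2c1` keeps the core of compound 1 and changes in one place, with nitro in place of hydroxy on an aromatic carbon, ortho to a methoxy group nitro in place of hydroxy on an aromatic carbon so that 3-hydroxy-4-methoxyphenyl becomes 4-methoxy-3-nitrophenyl.

Within the data shown here, the only measured single-place step is a 1.4-fold lower number from compound 1 to compound 3 (0.15 log units; within the scatter) for hydrogen in place of methyl on an aromatic carbon. It lies within the scatter and sits elsewhere on the molecule. Among the measured compounds shown here, no measured step replaces the hydroxy group, so the data bear on this change only indirectly. A nitro group also occurs in compound 2, which differs in other places too, and its reading of 17400 nM sits within the scatter of compound 1 and offers no sign of a large shift.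

No step beyond the scatter is therefore expected in this assay in either direction. The expected step is a 1.2-fold lower number from compound 1 to compound 4 (0.08 log units; within the scatter) and stays small. For compound 4 the estimated value is 15000 nM with an expected range from 6000 nM to 35000 nM in this read-out.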

Compound 4, half-maximal inhibitory concentration: 13600 nM
Beside the measured number, compound 4's estimate is 1.1-fold (0.04 log units) above it; the range from low to high includes it.
By their numbers in this assay, from the lowest: compounds 3, 4, 2 and 1 (each within the scatter of the next).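

The step at this position can now be read directly: nitro in place of hydroxy on an aromatic carbon, ortho to a methoxy group, gives a 1.3-fold lower number from compound 1 to compound 4 (0.12 log units; within the scatter) in this assay. The earlier compounds shown here offered only compound 2 as an indirect hint, since it carries a nitro group but differs in other places too. Here the change from 3-hydroxy-4-methoxyphenyl to 4-methoxy-3-nitrophenyl stands alone, and the loss of the hydrogen-bond donor leaves the reading within the scatter, with no measurement of any property of either group bearing on the result.

From the compounds shown here alone, with only this one replacement at the position, it stays open whether an amine, a carboxylic acid or a longer alkoxy chain in place of the hydroxy group would give a step beyond the scatter in this assay. Going by these compounds, it is also open whether the nitro-for-hydroxy step would stay this small on the core of compound 3, which lacks the methyl group.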